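Adding an Aryl Group to the Weakest Analogue

This account rests on a few compounds, and the source may have more. Where it says the series, first, only, none or still open, it means among the compounds named here.

Measured compounds:
compound 1, `CN(C)c1ccc(N2C(=O)NC3(CSC4=C3C(=O)c3ncccc3C4=O)C2=O)cc1`, 1 nM;
compound 2, `O=C1NNC(=O)C2(CSC3=C2C(=O)c2ncccc2C3=O)N1`, 450 nM;
compound 3, `O=C1C2=C(C(=O)c3ncccc31)C1(CS2)NC(=O)N(c2ccc(Cl)cc2)C1=O`, 10 nM.

In a functional assay on CCRF-CEM cells (Homo sapiens) for antiproliferative activity, read by MTT assay, with a stated time of 96 h (on this read-out lower numbers stand for stronger inhibition and higher numbers for weaker inhibition), compound 2 gives the highest number of the three, so it stands as the weakest inhibitor here. Compound 3 gives 10 nM, and compound 1 gives 1 nM, both far below compound 2.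

The new compound 4, `Cc1ccc(N2NC(=O)NC3(CSC4=C3C(=O)c3ncccc3C4=O)C2=O)cc1`, comes from compound 2 by the change (4-methylphenyl in place of hydrogen on an amide-type nitrogen in a ring). Going by the values given here, the only measured step that changes one place is a 10-fold higher number from compound 1 to compound 3 (1.00 log units; beyond the scatter), which swaps one substituent on an aryl ring already present; it does not add an aryl group to a bare ring nitrogen, so it bears on the present step only indirectly. What the numbers do show is that the two compounds carrying an aryl group on a ring nitrogen, compound 1 and compound 3, give far lower numbers than compound 2, which carries none. On that basis a drop in this assay is expected for compound 4, though its ring differs from theirs and the size is uncertain.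

Compound 4 is therefore expected to give 40 nM in this assay, within 6 nM to 250 nM, a step of an 11-fold lower number from compound 2 to compound 4 (1.05 log units; beyond the scatter) being the estimate.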

Compound 4, half-maximal inhibitory concentration: 70 nM
The estimate for compound 4 lay 1.8-fold (0.24 log units) below the measured number; low and high end bracket the measured number.
By their numbers in this assay, from the lowest: compound 1; then compound 3; then compound 4; then compound 2.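

In this assay the aryl group is now added directly on the amide-type nitrogen in the six-membered non-aromatic ring with 3 nitrogen, and this gives a 6.4-fold lower number from compound 2 to compound 4 (0.81 log units; beyond the scatter) on the bare ring. This shows on a single pair that the hydrogen at this position can be replaced by 4-methylphenyl with a gain in this assay beyond the scatter, whereas the earlier step, a 10-fold higher number from compound 1 to compound 3 (1.00 log units; beyond the scatter) in a different ring, only exchanged a substituent on an aryl ring already present. No measurement shown explains why the number falls at this position.

Going by these compounds alone, the single pair cannot separate the contribution of the aromatic ring from that of its methyl group, so an unsubstituted phenyl, a benzyl group or a longer chain such as n-butyl on the same nitrogen would be needed to tell how much of the step depends on the aryl ring itself. On these data alone, it also remains open how this ring nitrogen would respond to a carboxylic acid or an amine carried on the aryl ring in place of the methyl group.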